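A few compounds are considered here, and "the series" means these few. Any claim that something is new, unique, unknown or untested is made for them only; others in the source may bear on it.

Measured compounds:
- compound 1, `COc1cc2c(Oc3ccc(NC(=O)c4cn(-c5ccccc5)nn4)cc3F)ccnc2cc1OCCCN1CCCC1`: 180 nM
- compound 2, `COc1cc2c(Oc3ccc(NC(=O)c4cn(-c5ccccc5Cl)nn4)cc3F)ccnc2cc1OCCCN1CCCC1`: 150 nM
- compound 3, `COc1cc2c(Oc3ccc(NC(=O)c4cn(-c5ccccc5)nn4)cc3F)ccnc2cc1OCCCN1CCCCC1`: 180 nM

In a functional assay on HT-29 cells (Homo sapiens) for cytotoxicity, read by MTT assay, with a stated time of 72 h (on this read-out higher numbers stand for weaker inhibition and lower numbers for stronger inhibition), compound 3 sits level with compound 1 at the digits given, the two together being the highest numbers of the three, and compound 2 lies within the scatter of both. The step of no change at the digits printed from compound 1 to compound 3 (within the scatter) shows the exchange of the saturated ring at the chain end leaves the read-out unchanged.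

Compound 4, `COc1cc2c(Oc3ccc(NC(=O)c4cn(-c5c(C)cccc5C)nn4)cc3F)ccnc2cc1OCCCN1CCCCC1`, is not yet measured. It differs from compound 3 by 2,6-dimethylphenyl in place of phenyl on an aromatic nitrogen. For the measured compounds named here, the only measured step that touches the same phenyl is a 1.2-fold lower number from compound 1 to compound 2 (0.08 log units; within the scatter), a change well inside the scatter. Going by the values given here, no measured pair carries two methyl groups on that ring, so the present data give no direct precedent; the nearest step is small and points, if anywhere, to a slightly lower number. For compound 4 a step of about a 1.1-fold lower number from compound 3 to compound 4 (0.02 log units; within the scatter) is therefore expected, i.e. nothing beyond the scatter. The estimated value for compound 4 in this assay is 170 nM, with a range from 80 nM to 400 nM.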

Compound 4, half-maximal inhibitory concentration: 3690 nM
For compound 4 the middle estimate is 22-fold (1.34 log units) below the measured one; the whole stated range lies below it.
By their numbers in this assay, from the lowest: compounds 2, 1 and 3 (each within the scatter of the next); then compound 4.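

In this assay, for the compounds shown here, the phenyl on the aromatic nitrogen of the five-membered ring proves far less forgiving than the earlier compounds suggested: 2,6-dimethylphenyl in place of phenyl gives a 21-fold higher number from compound 3 to compound 4 (1.31 log units; beyond the scatter). Going by these compounds alone, the only earlier change on this ring, chloro in place of hydrogen, gave a 1.2-fold lower number from compound 1 to compound 2 (0.08 log units; within the scatter), so that small step does not carry over to 2,6-dimethylphenyl, and this position is the first to move the read-out beyond the scatter. No measurement at hand accounts for the rise.

Open, as far as these compounds go, is whether a single methyl group on the phenyl is enough for such a step, or whether two chloro groups in the places of the two methyl groups would give the same result. Also open, from the compounds shown here alone, is whether the step holds with pyrrolidin-1-yl at the chain end.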